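Aminopyrimidine hydroxamates: cyclopropyl replaces the aryl amine

The source may hold more compounds than are shown below. What is called first, only, known or untested is meant among the compounds shown, and "the series" means these compounds.

Compound 1 `O=C(CCCCCCn1cc(Nc2ncc(Cl)c(Nc3ccc(F)cc3)n2)cn1)NO` and compound 2 `COc1ccc(Nc2nc(Nc3cnn(CCCCCCC(=O)NO)c3)ncc2Cl)cc1` share one core. In a functional assay on K562 cells (Homo sapiens) for antiproliferative activity, read by MTT assay, with a stated time of 48 h (on this read-out higher numbers stand for weaker inhibition and lower numbers for stronger inhibition), compound 1 gives 500 nM; compound 2 gives 620 nM and so sits at the upper end of the two numbers, yet a 1.2-fold higher number from compound 1 to compound 2 (0.09 log units; within the scatter). Compound 3 `O=C(CCCCCCn1cc(Nc2ncc(Cl)c(NC3CC3)n2)cn1)NO` carries cyclopropyl in place of 4-methoxyphenyl on a nitrogen on an aromatic ring. Among the measured compounds shown here, that single measured step only alters a substituent on the aryl ring kept in both compounds; no step removes the ring itself, so there is no direct guide. A moderately higher number is nonetheless expected, a 2.4-fold higher number from compound 2 to compound 3 (0.38 log units; beyond the scatter). Compound 3 is estimated at 1500 nM, range 500 nM to 5000 nM.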

Compound 3, half-maximal inhibitory concentration: 380 nM
The estimate for compound 3 lay 3.9-fold (0.60 log units) above the measured number, outside the stated range (below it).
By their numbers in this assay, from the lowest: compounds 3, 1 and 2 (each within the scatter of the next).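

The earlier step only exchanged a substituent on the aryl ring; here the ring itself leaves the nitrogen on an aromatic ring. In this assay cyclopropyl in its place gives a 1.6-fold lower number from compound 2 to compound 3 (0.21 log units; within the scatter) and, against the 4-fluorophenyl compound, a 1.3-fold lower number from compound 1 to compound 3 (0.12 log units; within the scatter), so across these three compounds an aryl ring on this nitrogen is not needed for a number of this size. No supporting data bear on this result. Open, from the compounds shown here alone, is whether a smaller group such as methyl, or a larger ring such as cyclohexyl, on this nitrogen keeps the number in the same range.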